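A few compounds are considered here, and "the series" means these few. Any claim that something is new, unique, unknown or untested is made for them only; others in the source may bear on it.

In a functional assay on MDA-MB-231 cells (Homo sapiens), read by microscopy and transwell migration, with a stated time of 24 h (a higher number here means a weaker inhibitor, a lower number a stronger inhibitor), three compounds have been measured so far. Compound 1 `CCCCn1c(-c2ccc(C)cc2C)cs/c1=N\C(=O)c1ccccc1` gives 196 nM. Compound 2 `COc1cc(-c2csc(NC(=O)c3ccccc3)n2)cc(OC)c1OC` reaches only a limit of the assay, > 50000 nM, and not a true number. Compound 3 `COc1cc(-c2csc(N(C)C(=O)c3ccccc3)n2)cc(OC)c1OC` gives 10000 nM, the higher of the two true numbers, which makes it the weaker inhibitor of that pair. Its nearest neighbour, compound 1, lies well below it, and the gap is beyond the scatter.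

Compound 4 `COc1cccc(C(=O)N(C)c2nc(-c3cc(OC)c(OC)c(OC)c3)cs2)c1` keeps all of compound 3 except for one change, methoxy in place of hydrogen on an aromatic carbon, which turns phenyl to 3-methoxyphenyl: methoxy in place of hydrogen on an aromatic carbon.

Going by the values given here, only one measured step is available as a guide, an at least 5.0-fold lower number from compound 2 to compound 3 (0.69 log units; beyond the scatter). It came from methyl in place of hydrogen on an amide-type nitrogen, which is a different place and a different change. Among the compounds with values here, no measured step in this set shows what a methoxy does on the phenyl, so the size of that earlier step cannot simply be carried over. With no direct evidence for a shift in either direction, the expected change is a 1.4-fold lower number from compound 3 to compound 4 (0.15 log units; within the scatter), a step expected to stay within the usual scatter. Compound 4 is estimated at 7000 nM, with an expected range from 1000 nM to 35000 nM.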

Compound 4, half-maximal inhibitory concentration: 646 nM
The estimate for compound 4 lay 11-fold (1.03 log units) above the measured number, outside the stated range (below it).
By their numbers in this assay, from the lowest: compound 1; then compound 4; then compound 3. At a limit, above all of these: compound 2.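

In this assay, the phenyl proves to be a place where a small change counts: a 15-fold lower number from compound 3 to compound 4 (1.19 log units; beyond the scatter) comes from phenyl to 3-methoxyphenyl alone, an addition of only 2 heavy atoms. The earlier step showed a response only to a change on the amide-type nitrogen, whereas this one shows that an aromatic carbon of the phenyl, far from being a silent part of the molecule, can also move the number well beyond the scatter. The two steps cannot be ranked by size, since compound 2 stands at a limit and not at a true number: the limit of > 50000 nM in this assay, at which 1 of the 4 values shown sits.

The compounds shown carry just one group at one place on this phenyl, so it stays open whether a hydroxyl, a fluorine or a longer ethoxy group would act as methoxy does, and whether other places on the ring would respond in the same way. Also open, as far as these compounds go, is whether methoxy would lower the number as far with the amide hydrogen of compound 2 in place of the methyl.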